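This account rests on a few compounds, and the source may have more. Where it says the series, first, only, none or still open, it means among the compounds named here.

Measured so far:
compound 1 `O=C(Nc1ccccc1)Nc1nc(Sc2c[nH]c3ccccc23)cc(N2CCCC2)n1` — 7890 nM
compound 2 `O=C(Nc1ccccc1)Nc1nc(Sc2c[nH]c3ccccc23)cc(N2CCN(Cc3ccccc3)CC2)n1` — 10200 nM
compound 3 `O=C(Nc1ccccc1)Nc1nc(Nc2ccccc2)cc(Sc2c[nH]c3ccccc23)n1` — 35900 nM

In a functional assay on MDA-MB-231 cells (Homo sapiens) for inhibition, with a stated time of 72 h (on this read-out lower numbers stand for stronger inhibition and higher numbers for weaker inhibition), compound 3 gives 35900 nM, the highest of the three numbers. Compound 2 gives 10200 nM and compound 1 gives 7890 nM, each lower than compound 3 by a margin beyond the scatter, while the gap between compound 1 and compound 2 stays within it.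

Compound 4 `O=C(Nc1ccccc1)Nc1nc(Sc2c[nH]c3ccccc23)cc(N2CCN(c3ccccn3)CC2)n1` differs from compound 3 in one place: 4-(pyridin-2-yl)piperazin-1-yl in place of anilino on an aromatic carbon. Going by the values given here, only one measured step bears on this position, namely a 4.6-fold higher number from compound 1 to compound 3 (0.66 log units; beyond the scatter), in which anilino replaced pyrrolidin-1-yl and the number rose by a modest amount. Compound 4 runs that exchange the other way, replacing the anilino with a cyclic amine, and the closest measured analogue with a piperazine, compound 2, sits near compound 1 rather than near compound 3. Compound 4 is therefore expected to move back toward the lower numbers of the other two compounds. The expected step is a 3.6-fold lower number from compound 3 to compound 4 (0.56 log units; beyond the scatter), a drop beyond the scatter. Compound 4 is estimated to give 10000 nM in this assay, with a likely range from 3500 nM to 30000 nM.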

Compound 4, half-maximal inhibitory concentration: 19500 nM
Beside the measured number, compound 4's estimate is 2.0-fold (0.29 log units) below it; the range from low to high includes it.
By their numbers in this assay, from the lowest: compounds 1, 2, 4 and 3 (each within the scatter of the next, the first and the last beyond it).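

In this assay, the exchange at this position, a 1.8-fold lower number from compound 3 to compound 4 (0.27 log units; within the scatter), stays within the scatter, so replacing anilino with a cyclic amine does not in itself restore the lower numbers: the step between the two cyclic amines pyrrolidin-1-yl and 4-(pyridin-2-yl)piperazin-1-yl, a 2.5-fold higher number from compound 1 to compound 4 (0.39 log units; beyond the scatter), is modest but beyond the scatter. The group carried on the piperazine nitrogen makes no difference that these numbers can resolve, as pyridin-2-yl in place of benzyl gives a 1.9-fold higher number from compound 2 to compound 4 (0.28 log units; within the scatter), which is within the scatter. Nothing available here accounts for the difference between the two cyclic amines at this position.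

The compounds shown leave open whether the lower numbers follow the smaller pyrrolidine ring, which a dimethylamino group, an azetidine or a piperidine at the same carbon could test. They also leave open how a morpholine or a piperazine with only a hydrogen on its second nitrogen would compare with the groups seen so far.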